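Dechlorination of compound 3 at the cytotoxicity limit

A few compounds are considered here, and "the series" means these few. Any claim that something is new, unique, unknown or untested is made for them only; others in the source may bear on it.

Compound 1 `Cc1ccc2[nH]c(=O)c(-c3nc4cc([N+](=O)[O-])ccc4[nH]3)cc2c1` gives > 100000 nM in a functional assay on HepG2 cells (Homo sapiens) for cytotoxicity, read by MTT assay, with a stated time of 48 h (on this read-out lower numbers stand for stronger inhibition and higher numbers for weaker inhibition), a limit of the assay and not a number.
Compound 2 `COc1ccc2[nH]c(=O)c(-c3nc4cc(C)c(C)cc4[nH]3)cc2c1` gives > 100000 nM in this assay, again a limit.
Compound 3 `COc1ccc2[nH]c(=O)c(-c3nc4cc(Cl)ccc4[nH]3)cc2c1` gives > 100000 nM in this assay, also a limit.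

Compound 3 therefore stands at the limit of > 100000 nM in this assay, at which 3 of the 3 values shown sit, with no number of its own. Compound 4 `COc1ccc2[nH]c(=O)c(-c3nc4ccccc4[nH]3)cc2c1` differs from compound 3 by hydrogen in place of chloro on an aromatic carbon. For the measured compounds named here, no step between measured compounds exists here, so no size for such a change is known; with every measured value resting at the limit, no shift beyond the scatter is expected in this assay. Compound 4 is expected at 150000 nM, between 50000 nM and 500000 nM, most likely reported once more as a limit. The step this estimate means is expected to be a step that the limit leaves unreadable from compound 3 to compound 4, within scatter.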

Compound 4, half-maximal inhibitory concentration: > 100000 nM
Compound 4 was reported as a limit; the forecaster's own chance of this, stated with the estimate: 85%; the middle value is on the limit's open side.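

No step can be read from compound 3 to compound 4, as both results are limits of the assay and not numbers: the limit of > 100000 nM in this assay, at which 4 of the 4 values shown sit.

The compounds shown leave open whether any change to the shared core gives a number rather than a limit in this assay.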